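A few compounds are considered here, and "the series" means these few. Any claim that something is new, unique, unknown or untested is made for them only; others in the source may bear on it.

Among the compounds with values here, compound 2 `Cc1ccc(C(=O)Nc2nn[nH]n2)nc1` stands at the top of the two numbers so far gathered: in a functional assay on the whole organism for inhibition, with Rattus norvegicus as the target, at a dose of 10 mg/kg by the oral route (on this read-out higher numbers stand for a stronger effect at the one dose given and lower numbers for a weaker effect), compound 2 gives 42%. Its nearest neighbour is compound 1 `Cc1cc([N+](=O)[O-])cc(C(=O)Nc2nn[nH]n2)n1`, which in this assay gives 6%, a gap that lies beyond the scatter of this kind of measurement. Within the data shown here, the two compounds differ in more than one place, so no single-point step between measured compounds is available, and what they show is only that the two values sit far apart. The next compound, compound 3 `O=C(Nc1nn[nH]n1)c1ccccn1`, differs from compound 2 by hydrogen in place of methyl on an aromatic carbon. Among the measured compounds shown here, with no measured step to lean on, the expected step from compound 2 to compound 3 is taken to be small, a number 7 percentage points lower from compound 2 to compound 3 (within the scatter), most likely within the scatter and, if anything, a modest loss. Compound 3 is therefore estimated to give about 35% in this assay, with a range from 15% to 55%.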

Compound 3, a percentage reported as inhibition, in the whole organism at one dose (the size of the read-out at that dose, not a potency): 35%
The estimate for compound 3 equals the measured number at the digits printed; the measured number falls inside the stated range.
By their numbers in this assay, from the lowest: compound 1; then compounds 3 and 2 (each within the scatter of the next).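

In this assay, hydrogen in place of methyl gives a number 7 percentage points lower from compound 2 to compound 3 (within the scatter), the first step among these compounds that can be read at a single place. At this aromatic carbon, two atoms from the ring nitrogen and para to a group of 8 heavy atoms, the methyl therefore makes no difference beyond the scatter at the one dose given. No measurement of any other kind is available to account for this result.

From the compounds shown here alone, it remains open how the read-out would respond to a methoxy group, an amine or a carboxylic acid on this same carbon. Going by these compounds, it also remains open whether hydrogen in place of methyl would give a similarly small step on the other carbons of the ring.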